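Chloro for trifluoromethyl on the core of compound 1

This account rests on a few compounds, and the source may have more. Where it says the series, first, only, none or still open, it means among the compounds named here.

Compound 1, `CC(C)(C)[C@H]1CC[C@]2(CC1)N=C(c1ccc(C(F)(F)F)cc1)C(=O)N2Cc1ccc(C(=O)NCCC(=O)O)cc1`, is the weakest of the three measured compounds on the numbers shown: in a functional assay on CHO cells for antagonist activity at Glucagon receptor (Homo sapiens), read by cAMP accumulation, with stated times of 30 min and 45 min (a higher number here means a weaker inhibitor, a lower number a stronger inhibitor), compound 1 gives 800 nM. Compound 2, `CC(C)(C)CC[C@H](c1ccc(C(=O)NCc2nn[nH]n2)cc1)N1C(=O)C(c2cncc(Cl)c2)=N[C@]12CC[C@@H](C(C)(C)C)CC2`, gives 480 nM in this assay, a number within the scatter of compound 1, while compound 3, `CC(C)(C)CC[C@H](c1ccc(C(=O)NCc2nn[nH]n2)cc1)N1C(=O)C(c2cccc(C(F)(F)F)c2)=N[C@]12CC[C@@H](C(C)(C)C)CC2`, gives 180 nM, beyond the scatter from compound 1.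

Compound 4, `CC(C)(C)[C@H]1CC[C@]2(CC1)N=C(c1cccc(Cl)c1)C(=O)N2Cc1ccc(C(=O)NCCC(=O)O)cc1`, differs from compound 1 in one place: 3-chlorophenyl in place of 4-(trifluoromethyl)phenyl on a carbon with a double bond to nitrogen.

Among the compounds with values here, only one measured step touches this kind of exchange. It is a 2.7-fold lower number from compound 2 to compound 3 (0.43 log units; beyond the scatter), where a group bearing chlorine gave way to one bearing trifluoromethyl and the number fell. The present change runs the opposite way, trading trifluoromethyl for chlorine, though on a different core and with the groups attached at different places, so it is a loose guide.

Compound 4 is therefore expected to be a somewhat weaker inhibitor than compound 1, with an estimated 1.6-fold higher number from compound 1 to compound 4 (0.21 log units; within the scatter). The estimate for compound 4 in this assay is 1300 nM, with a range from 450 nM to 3800 nM.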

Compound 4, half-maximal inhibitory concentration: 770 nM
Beside the measured number, compound 4's estimate is 1.7-fold (0.23 log units) above it; measured number inside the range.
By their numbers in this assay, from the lowest: compound 3; then compounds 2, 4 and 1 (each within the scatter of the next).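

The step of a 1.0-fold lower number from compound 1 to compound 4 (0.02 log units; within the scatter) is read in this assay and shows that, on the core of compound 1, 3-chlorophenyl and 4-(trifluoromethyl)phenyl cannot be told apart at this carbon with a double bond to nitrogen. The earlier step of a 2.7-fold lower number from compound 2 to compound 3 (0.43 log units; beyond the scatter) stands on a different core and starts from 5-chloropyridin-3-yl, and this new result shows that its drop in number does not carry over to this exchange. Because the substituent and its place on the phenyl ring change together here, the result cannot separate the two.

Still open, going by these compounds, is how a plain phenyl, or a phenyl bearing a methoxy group or an amine, would read at this carbon on the same core. Nothing measured here offers an explanation for this result.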